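A few compounds are considered here, and "the series" means these few. Any claim that something is new, unique, unknown or untested is made for them only; others in the source may bear on it.

Working notes on the series. Compound 1 `N#Cc1c(-c2ccc(Cl)cc2)nc(SCC(=O)Nn2c(COc3ccc(Cl)cc3Cl)nc3ccccc3c2=O)n(Cc2ccccc2)c1=O` and compound 2 `N#Cc1c(-c2ccc(O)cc2)nc(SCC(=O)Nn2c(COc3ccc(Cl)cc3Cl)nc3ccccc3c2=O)n(Cc2ccccc2)c1=O` share one core; compound 3 `N#Cc1c(Nc2ccccc2)nc(SCC(=O)Nn2c(COc3ccc(Cl)cc3Cl)nc3ccccc3c2=O)nc1-c1ccc(Cl)cc1` and compound 4 `N#Cc1c(Nc2ccccc2)nc(SCC(=O)Nn2c(COc3ccc(Cl)cc3Cl)nc3ccccc3c2=O)nc1-c1ccc(O)cc1` share another. The difference between the two cores is not broken down here.

In a functional assay on the whole organism (strain albino) for inhibition, with Rattus norvegicus as the target, read by paw edema, with stated times of 1 h and 3 h, at a dose of 100 mg/kg by the oral route (a lower number here means a weaker effect, a higher number a stronger effect of the compound at the dose given), compound 1 gives 77.2%. In this assay compound 2 gives 61.4%. The change between them is hydroxy in place of chloro on an aromatic carbon. The measured step is a number 15.8 percentage points lower from compound 1 to compound 2 (beyond the scatter).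

In this assay compound 3 gives 56.1%. Set against compound 2 this number lies within the scatter; set against compound 1 it lies beyond it.

The change from compound 3 to compound 4 is hydroxy in place of chloro on an aromatic carbon. It is the same change as that from compound 1 to compound 2, at the same kind of place, and it occurs twice among the four compounds. Only one of the two occurrences is measured, and that one sits on a different core, so the expectation for compound 4 rests on a single precedent carried across cores.

Within the data shown here, the step from compound 3 to compound 4 is estimated at a number 11.1 percentage points lower from compound 3 to compound 4 (beyond the scatter) because the sole precedent is a number 15.8 percentage points lower from compound 1 to compound 2 (beyond the scatter) and a step of similar direction and somewhat smaller size is assumed. Compound 4 is therefore expected to give 45% in this assay, with the likely range running from 32% to 58%.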

Compound 4, a percentage reported as inhibition, in the whole organism at one dose (the size of the read-out at that dose, not a potency): 91.2%
Compound 4: the middle estimate sits 46.2 percentage points below what was measured, and the stated range ends below it.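

The exchange of 4-chlorophenyl for 4-hydroxyphenyl yields a number 35.1 percentage points higher from compound 3 to compound 4 (beyond the scatter) in this assay, so the precedent on the core of compound 1 does not predict the direction of the step on the core of compound 3. In this series, the same change does not carry from one core to the other in either sign or size: the same change on two cores in this assay, a number 15.8 percentage points lower (beyond the scatter) from compound 1 to compound 2 and a number 35.1 percentage points higher (beyond the scatter) from compound 3 to compound 4, 50.9 percentage points apart, beyond the scatter of two such steps. This shows that the effect of the change depends on its core for these two pairs, but it does not show which of the differences between the cores is responsible, whether the opposite steps would recur in other matched pairs, or whether they would persist at another dose, since the read-out is the size of the effect at one dose and not a potency.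

Only chloro and hydroxy are shown at this place, which leaves open whether a methoxy group, an amine or a carboxylic acid there would also give steps that differ between the two cores. Also open is which part of the difference between the cores matters, as no compounds shown separate its individual elements.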